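Swapping a Methoxy for Hydrogen on Compound 2

The compounds below may be only part of what the source reports. "The series", "measured", "known", "first", "only" and "open" are said of these compounds alone.

Of the compounds shown here, three have been measured so far in a functional assay on PC-3 cells (Homo sapiens) for cytotoxicity, read by MTT assay, with a stated time of 72 h; a lower number here means a stronger inhibitor, a higher number a weaker inhibitor. Compound 1 `COc1ccc(/C=C/C(=O)OC/C=C/c2ccc(OC)c(OC)c2)cc1` gives 181000 nM and compound 3 `COCOc1ccc(/C=C/C(=O)OC/C=C/c2ccc(OC)cc2)cc1` gives 226000 nM as its reading. Compound 2 `COc1ccc(CCCOC(=O)CCc2ccc(O)cc2)cc1` gives 283000 nM and so stands within the usual scatter of both others. Repeat measurements of a single compound can differ by this much, so these three readings cannot be told apart, even though the structures are not the same.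

Compound 4 `O=C(CCc1ccc(O)cc1)OCCCc1ccccc1` has not been measured yet. It differs from compound 2 by one change, hydrogen in place of methoxy on an aromatic carbon, para to a large group (hydrogen in place of methoxy on an aromatic carbon). Within the data shown here, no measured pair of compounds differs in one place only, so the data show nothing about this swap taken alone. The nearest guide is compound 2 itself at 283000 nM as the starting point, and no step beyond the scatter is expected in either direction. The estimated change is a 1.1-fold lower number from compound 2 to compound 4 (0.04 log units; within the scatter) and that is too small to count as a real difference. For compound 4 the expected value is 260000 nM with an estimated range from 120000 nM to 500000 nM as its likely span.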

Compound 4, half-maximal inhibitory concentration: 322000 nM
For compound 4 the middle estimate is 1.2-fold (0.09 log units) below the measured one; the measured number falls inside the stated range.
By their numbers in this assay, from the lowest: compounds 1, 3, 2 and 4 (each within the scatter of the next).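

In this assay, replacing the methoxy on an aromatic carbon, para to a large group, with hydrogen gives a 1.1-fold higher number from compound 2 to compound 4 (0.06 log units; within the scatter). Among these compounds, compound 2 and compound 4 are the first pair here that differ in one place only, so this swap can now be read on its own: the whole methoxy, with its carbon and its oxygen, can go from this position without a change that can be told from repeat-measurement noise, at least on this core and in this assay. The data offer no independent measurement that could explain this result.

As far as these compounds go, the comparison covers only methoxy and hydrogen at this position, so it remains open whether a different group there, such as an amine, a carboxylic acid or a longer chain ending in a phenyl ring, would move the reading beyond the scatter. From the compounds shown here alone, it is also open whether the same swap would behave alike on a different scaffold, such as the core of compound 1, where the link between the two aromatic rings is not the same.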